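Swapping Chloro for Nitro on a Shared Hydrazone Core

This account rests on a few compounds, and the source may have more. Where it says the series, first, only, none or still open, it means among the compounds named here.

Compound 2 `Clc1ccc(NN=C(c2nc3ccccc3[nH]2)c2nc3ccccc3[nH]2)cc1` gives 16800 nM in a functional assay on HCT-116 cells (Homo sapiens) for cytotoxicity, read by MTT assay, with a stated time of 72 h (a higher number here means a weaker inhibitor, a lower number a stronger inhibitor), and compound 1 `c1ccc(NN=C(c2nc3ccccc3[nH]2)c2nc3ccccc3[nH]2)cc1` gives 17600 nM in this assay; the two numbers lie within the scatter of each other, so neither stands apart. Within the data shown here, the only measured step, a 1.0-fold lower number from compound 1 to compound 2 (0.02 log units; within the scatter), is therefore essentially flat. Compound 3 `O=[N+]([O-])c1ccc(NN=C(c2nc3ccccc3[nH]2)c2nc3ccccc3[nH]2)cc1` differs from compound 2 by nitro in place of chloro on an aromatic carbon. Among the measured compounds shown here, no measured step covers a nitro group, so the flat step between compound 1 and compound 2 is the only guide, and it suggests little movement. Compound 3 is expected to give about 15000 nM, with a range from 6000 nM to 40000 nM. The expected step of a 1.1-fold lower number from compound 2 to compound 3 (0.05 log units; within the scatter) is thus estimated to stay within the scatter.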

Compound 3, half-maximal inhibitory concentration: 4700 nM
For compound 3 the middle estimate is 3.2-fold (0.50 log units) above the measured one; measured number outside the range, below it.
By their numbers in this assay, from the lowest: compound 3; then compounds 2 and 1 (each within the scatter of the next).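

In this assay, nitro at this place gives a 3.6-fold lower number from compound 2 to compound 3 (0.55 log units; beyond the scatter), and measured against the bare ring it gives a 3.7-fold lower number from compound 1 to compound 3 (0.57 log units; beyond the scatter). So this carbon, para to a large group, is not indifferent to what it carries, which the flat step with chloro could not reveal. No measurement available here explains the change. As far as these compounds go, whether an amine or a carboxylic acid at this place would lower the number, leave it unchanged or raise it stays open. So does whether a nitrile would behave like nitro or like chloro.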